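Chloro to Methylsulfanyl: What Compound 4 Might Show

A few compounds are considered here, and "the series" means these few. Any claim that something is new, unique, unknown or untested is made for them only; others in the source may bear on it.

Of the compounds shown here, three built on one shared core have been tested in a functional assay on HL-60 cells (Homo sapiens) for antiproliferative activity, read by MTT assay, with a stated time of 48 h; a lower number here means a stronger inhibitor, a higher number a weaker inhibitor. Compound 1 `O=C1C(Cl)=C(Cl)C(=O)c2ncccc21` gives 31800 nM. Compound 2 `CNC1=C(Cl)C(=O)c2ncccc2C1=O` gives 2450 nM, and compound 3 `CNC1=C(Cl)C(=O)c2cccnc2C1=O` gives 4300 nM. Compound 3 stands second highest of the three numbers: a 7.4-fold lower number from compound 1 to compound 3 (0.87 log units; beyond the scatter) sets it well apart from compound 1, while its gap to compound 2 lies within the scatter, so those two cannot be ranked against each other. Compound 4 `CNC1=C(SC)C(=O)c2cccnc2C1=O` differs from compound 3 in one place: methylsulfanyl in place of chloro on a double-bonded ring carbon. Among the compounds with values here, no measured step covers this exact swap. Within the data shown here, the only steps on record replace a chloro on a double-bonded ring carbon with methylamino, namely a 13-fold lower number from compound 1 to compound 2 (1.11 log units; beyond the scatter) and a 7.4-fold lower number from compound 1 to compound 3 (0.87 log units; beyond the scatter), both beyond the scatter; methylsulfanyl is a different group, so those steps give only a loose hint about direction. The step from compound 3 to compound 4 is expected to be small, a 1.2-fold lower number from compound 3 to compound 4 (0.09 log units; within the scatter), quite possibly within the scatter. Compound 4 is therefore estimated at 3500 nM in this assay, with a range from 1200 nM to 10000 nM.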

Compound 4, half-maximal inhibitory concentration: 7920 nM
The estimate for compound 4 lay 2.3-fold (0.35 log units) below the measured number; low and high end bracket the measured number.
By their numbers in this assay, from the lowest: compounds 2, 3 and 4 (each within the scatter of the next, the first and the last beyond it); then compound 1.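

Placing methylsulfanyl where chloro stood on this double-bonded ring carbon, with the methylamino group next to it unchanged, gives a 1.8-fold higher number from compound 3 to compound 4 (0.27 log units; within the scatter) in this assay so the swap cannot be told apart from no change at all. Until now this carbon had been seen carrying only chloro, and compound 4 shows that a group of 2 heavy atoms, one of them sulfur, can stand there without a step beyond the scatter. No measurement at hand accounts for this result.

From the compounds shown here alone, whether a different group on this carbon, such as a longer chain like butylsulfanyl, a methoxy group or an amine, would move the number beyond the scatter remains open. Going by these compounds, it also remains open whether the same swap on compound 2 would give a similar step.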